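The source may hold more compounds than are shown below. What is called first, only, known or untested is meant among the compounds shown, and "the series" means these compounds.

Of the compounds shown here, two have been measured in an ADME assay on A549 cells (Homo sapiens) for cytotoxicity, read by resazurin assay, with a stated time of 48 h; a lower number here means that less compound is tolerated, a higher number that more compound is tolerated. Compound 1 `CC(C)(C)OC(=O)N1CCN(C(=O)Nc2ccc([N+](=O)[O-])cc2)C(c2ccccc2)C1` gives 161000 nM in this assay. Compound 2 `CC1CN(C(=O)CC2CCCCC2)CCN1C(=S)Nc1ccc(Cl)cc1` gives 200000 nM; of the two numbers it is the one that stands higher, yet its gap to compound 1 is within the usual scatter, so the two cannot be told apart. Compound 3 `Cc1ccc(NC(=S)N2CCN(C(=O)CC3CCCCC3)CC2C)cc1` differs from compound 2 by methyl in place of chloro on an aromatic carbon. For the measured compounds named here, no measured step of this kind exists, so the step from compound 2 to compound 3 is expected to be a 1.1-fold lower number from compound 2 to compound 3 (0.02 log units; within the scatter), none beyond the scatter. Compound 3 is estimated at 190000 nM, between 90000 nM and 400000 nM.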

Compound 3, half-maximal cytotoxic concentration: 122000 nM
Compound 3: the middle estimate sits 1.6-fold (0.19 log units) above what was measured; the measured number falls inside the stated range.
By their numbers in this assay, from the lowest: compounds 3, 1 and 2 (each within the scatter of the next).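

In this assay, for the compounds shown here, the pair gives the first step that can be read, with methyl in place of chloro on the aromatic carbon para to a large group: a 1.6-fold lower number from compound 2 to compound 3 (0.21 log units; within the scatter). At this position, the 4-chlorophenyl and 4-methylphenyl compounds cannot be told apart. No measurement at hand bears on why. As far as these compounds go, it remains open whether another group at the same place, such as an amine or a carboxylic acid, would give a number beyond the scatter.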